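A Benzyl Ether Change Measured in Cell Inhibition

The source may report more compounds than this note shows. Statements on the series, on what has been measured and on what is new or still open speak of the compounds shown alone.

Compound 1 `Cc1ccc(NC(=S)NC(=O)c2ccc(OCc3cccc(Cl)c3)cc2)cc1-c1nc2ccccc2[nH]1`: > 100000 nM (a limit)
Compound 2 `O=C(NC(=S)Nc1ccc(Cl)c(-c2nc3ccccc3[nH]2)c1)c1ccc(OCc2ccc(C(F)(F)F)cc2)cc1`: 63900 nM
Compound 3 `Cc1ccc(NC(=O)NC(=O)c2ccc(OCc3ccc(C(F)(F)F)cc3)cc2)cc1-c1nc2ccccc2[nH]1`: 15300 nM

Of the compounds shown here, three have been measured in a functional assay on SW-620 cells (Homo sapiens) for inhibition, read by MTT assay, with a stated time of 48 h; a higher number here means a weaker inhibitor, a lower number a stronger inhibitor. Compound 1 reaches only the limit of the assay, > 100000 nM, and so gives no number (the limit of > 100000 nM in this assay, at which 1 of the 3 values shown sits). Compound 2 gives 63900 nM, and compound 3 gives 15300 nM, the lowest of the two numbers; the gap from compound 3 to compound 2 lies beyond the usual scatter. No two of the measured compounds differ in only one place, so no single step can be read from them.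

Compound 4 `Cc1ccc(NC(=O)NC(=O)c2ccc(OCc3ccc(Cl)c(Cl)c3)cc2)cc1-c1nc2ccccc2[nH]1` is not yet measured. It differs from compound 3 in one place: 3,4-dichlorophenyl in place of 4-(trifluoromethyl)phenyl on a saturated chain carbon bound to an oxygen on an aromatic ring. For the measured compounds named here, since no measured pair isolates a change of this kind, the size of the step is uncertain; the two groups are both halogenated aromatic rings of similar bulk, and the expectation is a change in this assay no larger than the scatter, in either direction. Compound 4 is therefore expected to give 13000 nM, within a range from 4000 nM to 45000 nM. The step from compound 3 to compound 4 is thus estimated at a 1.2-fold lower number from compound 3 to compound 4 (0.07 log units; within the scatter).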

Compound 4, half-maximal inhibitory concentration: 6100 nM
Compound 4: middle estimate off by 2.1-fold (0.33 log units), on the high side; measured number inside the range.
By their numbers in this assay, from the lowest: compound 4; then compound 3; then compound 2. At a limit, above all of these: compound 1.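

In this assay, 3,4-dichlorophenyl in place of 4-(trifluoromethyl)phenyl on a saturated chain carbon bound to an oxygen on an aromatic ring gives a 2.5-fold lower number from compound 3 to compound 4 (0.40 log units; beyond the scatter), a modest step but one that lies beyond the usual scatter. For the compounds shown here, this is the first change that can be read on its own, since no earlier pair differed in only one place, and it shows that the number responds to the ring at this position while the rest of compound 4 stays the same as in compound 3. Nothing measured here accounts for the step, and the data offer no explanation for it.

The compounds shown leave open whether either chlorine alone would give the same step, and whether a ring bearing a methoxy group, an amine or a carboxylic acid would move the number further in either direction. Going by these compounds alone, compound 1 and compound 2 each differ from compound 3 and compound 4 in more than one place, so no steps involving them can be read, and the result at this position stands on a single pair.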